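The source may report more compounds than this note shows. Statements on the series, on what has been measured and on what is new or still open speak of the compounds shown alone.

Measured so far:
compound 1, `Cc1cccc(N2CCN(c3cc(C(F)(F)F)ccc3CNC(=O)C(C)c3ccc(NS(C)(=O)=O)c(F)c3)CC2)c1`: 1.8 nM
compound 2, `CC(C)CCOc1cc(C(F)(F)F)ccc1CNC(=O)C(C)c1ccc(NS(C)(=O)=O)c(F)c1`: 0.5 nM

Both numbers come from an assay on CHO cells for antagonist activity at transient receptor potential cation channel subfamily V member 1 (Homo sapiens), read by FLIPR; on this read-out lower numbers stand for stronger inhibition and higher numbers for weaker inhibition. Compound 2 holds the lower of the two numbers, and compound 1 gives the higher one, with a gap that lies beyond the scatter of repeated measurement. For the measured compounds named here, no single-point step between these two compounds is computed, since they differ in more than one place.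

Compound 3, `CC(C(=O)NCc1ccc(C(F)(F)F)cc1F)c1ccc(NS(C)(=O)=O)c(F)c1`, has not yet been measured. It differs from compound 2 as follows: fluoro in place of isopentyloxy on an aromatic carbon The isopentyloxy group leaves and fluoro enters on the same aromatic carbon. Going by the values given here, no measured step of this kind exists in the set, so the expectation rests on the structural change alone. An upward step, beyond the scatter, is expected. The expected step is a 30-fold higher number from compound 2 to compound 3 (1.48 log units; beyond the scatter). For compound 3 the estimate is 15 nM, within a range of 3 nM to 80 nM.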

Compound 3, inhibition constant: 68.7 nM
Compound 3: middle estimate off by 4.6-fold (0.66 log units), on the low side; the range from low to high includes it.
By their numbers in this assay, from the lowest: compound 2; then compound 1; then compound 3.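

In this assay, the aromatic carbon ortho to a large group and meta to a trifluoromethyl group proves highly sensitive to its substituent: fluoro in place of isopentyloxy gives a 140-fold higher number from compound 2 to compound 3 (2.14 log units; beyond the scatter). For the compounds shown here, this is the only one-place step in the set, and it shows that a single fluoro atom does not stand in for the isopentyloxy group at this position without a large loss of inhibition. Nothing measured here explains the size of this step.

Going by these compounds, whether the loss tracks the length of the chain or the loss of the ether oxygen remains open, since only these two groups are joined by a step. Methoxy, a longer alkoxy chain or a simple amine such as dimethylamino on the same carbon would help separate these readings.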